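Ethoxy to trifluoromethoxy on the shared core

A few compounds are considered here, and "the series" means these few. Any claim that something is new, unique, unknown or untested is made for them only; others in the source may bear on it.

Among the measured compounds shown here, in an ADME assay on a cell-free system (plasma, Mus musculus) for protein binding, read by LC-MS, with a stated time of 5 h, compound 1 `C=CCOc1ccc(C2CC(=O)Nc3nc(N)[nH]c(=O)c32)cc1OC` gives 49.5% and compound 2 `CCOc1cccc(C2CC(=O)Nc3nc(N)[nH]c(=O)c32)c1` gives 52.6% so compound 2 stands within the scatter of its only neighbour. Compound 3 `Nc1nc2c(c(=O)[nH]1)C(c1cccc(OC(F)(F)F)c1)CC(=O)N2` carries trifluoromethyl in place of ethyl on an oxygen on an aromatic ring. For the measured compounds named here, no measured pair differs in one place only, so no measured step guides this one. A small move towards more binding is expected (a 1.4-fold lower unbound fraction from compound 2 to compound 3 (0.13 log units; within the scatter)) and it is not expected to pass beyond the scatter. In this assay the estimate for compound 3 is 65% (range 50% to 80%).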

Compound 3, plasma protein binding: 70.2%
For compound 3 the middle estimate is 1.2-fold (0.07 log units) (unbound fraction) above the measured one, and the stated range covers the measured number.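

In this assay, among the compounds shown here, the only pair that differs in one place gives a 1.6-fold lower unbound fraction from compound 2 to compound 3 (0.20 log units; within the scatter). On the shared core, trifluoromethyl in place of ethyl on an oxygen on an aromatic ring therefore stays inside the scatter of plasma protein binding, though this rests on a single pair. Nothing measured here bears on the reason for this step. Still open, going by these compounds, is whether a longer chain on that oxygen, or an amine in place of the ethoxy, would give a step beyond the scatter.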